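Aryl exchange on a flat series

This account rests on a few compounds, and the source may have more. Where it says the series, first, only, none or still open, it means among the compounds named here.

In an ADME assay on L02 cells (Homo sapiens) for cytotoxicity, read by MTT assay, with a stated time of 24 h (a higher number here means a weaker inhibitor, a lower number a stronger inhibitor), compound 3 `COc1cc(/C=C2\CN(S(=O)(=O)c3ccc(F)cc3)C/C(=C\c3ccccc3F)C2=O)cc(OC)c1` gives 18500 nM, compound 1 `COc1cc(/C=C2\CN(S(=O)(=O)c3ccc(F)cc3)C/C(=C\c3cc(OC)cc(OC)c3)C2=O)cc(OC)c1` gives 19800 nM and compound 2 `COc1cc(/C=C2\CN(S(=O)(=O)c3ccc(F)cc3)C/C(=C\c3ccccc3F)C2=O)cc(OC)c1OC` gives 17600 nM, so compound 3 lies within the scatter of both others. Compound 4 `COc1cc(/C=C2\CN(S(=O)(=O)c3ccc(F)cc3)C/C(=C\c3cc(OC)c(OC)c(OC)c3)C2=O)cc(OC)c1` differs from compound 3 by 3,4,5-trimethoxyphenyl in place of 2-fluorophenyl on a double-bonded chain carbon bound to a double-bonded ring carbon, with 3,4,5-trimethoxyphenyl in place of 2-fluorophenyl. Among the measured compounds shown here, two measured steps bear on this: the aryl exchange at the same place, a 1.1-fold lower number from compound 1 to compound 3 (0.03 log units; within the scatter), and hydrogen in place of methoxy on an aromatic carbon, a 1.1-fold higher number from compound 2 to compound 3 (0.02 log units; within the scatter). Neither leaves the scatter, so no shift beyond it is expected in this assay. The expected step is a 1.0-fold higher number from compound 3 to compound 4 (0.01 log units; within the scatter). For compound 4 the estimated value is 19000 nM, with an expected range of 12000 nM to 30000 nM.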

Compound 4, half-maximal inhibitory concentration: 12300 nM
Compound 4: middle estimate off by 1.5-fold (0.19 log units), on the high side, within the range that was stated.
By their numbers in this assay, from the lowest: compounds 4, 2, 3 and 1 (each within the scatter of the next).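

In this assay, 3,4,5-trimethoxyphenyl in place of 2-fluorophenyl on a double-bonded chain carbon bound to a double-bonded ring carbon gives a 1.5-fold lower number from compound 3 to compound 4 (0.18 log units; within the scatter), so even this larger group with 3 hydrogen-bond acceptors produces no readable shift. The aryl exchange on the second core, a 1.4-fold lower number from compound 2 to compound 4 (0.16 log units; within the scatter), agrees with the exchange on the first: the same change on two cores in this assay, a 1.1-fold lower number (0.03 log units; within the scatter) from compound 1 to compound 3 and a 1.4-fold higher number (0.16 log units; within the scatter) from compound 4 to compound 2, 1.5-fold (0.19 log units) apart, within the scatter of two such steps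

The methoxy change, a 1.6-fold lower number from compound 1 to compound 4 (0.21 log units; within the scatter), likewise reads alike on two cores: the same change on two cores in this assay, a 1.1-fold higher number (0.02 log units; within the scatter) from compound 2 to compound 3 and a 1.6-fold higher number (0.21 log units; within the scatter) from compound 4 to compound 1, 1.5-fold (0.19 log units) apart, within the scatter of two such steps

On these data alone, whether an amine or a carboxylic acid at this position would move the number beyond the scatter remains open. So does whether any group here gives a step that can be read in this assay.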